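From Compound 2 to Compound 3: Removing an Amine Chain

The source may report more compounds than this note shows. Statements on the series, on what has been measured and on what is new or still open speak of the compounds shown alone.

In a functional assay on A549 cells (Homo sapiens) for antiproliferative activity, with a stated time of 72 h (a lower number here means a stronger inhibitor, a higher number a weaker inhibitor), compound 2 `COc1cc(OC)c(C(=O)/C=C/c2ccccc2Cl)c(O)c1CN(C)CCCN(C)C` gives 3100 nM. Within the data shown here, only one other measured compound stands beside it, compound 1 `COc1cc(OC)c(C(=O)/C=C/c2ccccc2Cl)c(O)c1CN1CCCC1`, which gives 2600 nM, and these two values lie within the scatter of each other.

The next compound, compound 3 `COc1cc(OC)c(C(=O)/C=C/c2ccccc2Cl)c(O)c1CN(C)C`, has not yet been measured. Its structure differs from that of compound 2 by hydrogen in place of 2-(dimethylamino)ethyl on a saturated chain carbon bound to an amine nitrogen. Cut one bond further out, this reads as 3-(dimethylamino)propyl to methyl.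

Among the measured compounds shown here, one measured step bears on this change: a 1.2-fold higher number from compound 1 to compound 2 (0.08 log units; within the scatter), where (3-(dimethylamino)propyl)(methyl)amino takes the place of pyrrolidin-1-yl. That step also alters the amine, but it is a single comparison and a different exchange, so it offers only limited guidance. On this evidence, no step beyond the scatter is expected in this assay, in either direction.

The expected step is a 1.0-fold lower number from compound 2 to compound 3 (0.01 log units; within the scatter). Compound 3 is estimated at 3000 nM, with an expected range of 1300 nM to 7000 nM.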

Compound 3, half-maximal inhibitory concentration: 2100 nM
Compound 3: middle estimate off by 1.4-fold (0.15 log units), on the high side; the measured number falls inside the stated range.
By their numbers in this assay, from the lowest: compounds 3, 1 and 2 (each within the scatter of the next).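

In this assay, cutting the side arm back to dimethylamino gives a 1.5-fold lower number from compound 2 to compound 3 (0.17 log units; within the scatter), so the 2-(dimethylamino)ethyl group, with its 5 heavy atoms and its hydrogen-bond acceptor, can give way to hydrogen on this saturated chain carbon bound to an amine nitrogen without a step beyond the scatter. Among these compounds, the comparison with the ring amine gives a 1.2-fold lower number from compound 1 to compound 3 (0.09 log units; within the scatter), and with this step all three pairs among compounds 1, 2 and 3 are printed as within the scatter, so pyrrolidin-1-yl, (3-(dimethylamino)propyl)(methyl)amino and dimethylamino cannot be told apart here, where the earlier compounds offered only a single pair. No other measurement is available to account for how closely these numbers stay together.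

The compounds shown leave open whether a morpholine, a piperazine or a longer chain ending in a carboxylic acid would also stay within the scatter at this place. They also leave open whether an amide in place of the amine, or the removal of the whole (dimethylamino)methyl group from the shared core, would move the number at all.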